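Ester Variation at the Imidazole Carboxylate of Compound 3

This account rests on a few compounds, and the source may have more. Where it says the series, first, only, none or still open, it means among the compounds named here.

Measured so far:
compound 1 `CCCc1nc(CC)c(C(=O)OCCCOCc2ccccc2)n1Cc1ccc(-c2ccccc2S(=O)(=O)NC(=O)OCCC(C)C)cc1F`: 2 nM
compound 2 `CCCc1nc(CC)c(C(=O)OCc2ccccc2NC(=O)c2ccccc2)n1Cc1ccc(-c2ccccc2S(=O)(=O)NC(=O)OCCC(C)C)cc1F`: 1 nM
compound 3 `CCCc1nc(CC)c(C(=O)OCCCCOc2ccccc2)n1Cc1ccc(-c2ccccc2S(=O)(=O)NC(=O)OCCC(C)C)cc1F`: 2 nM

In an assay on isolated protein for binding affinity to Type-2 angiotensin II receptor (Homo sapiens) (on this read-out higher numbers stand for weaker inhibition and lower numbers for stronger inhibition), compound 3 gives 2 nM, level with compound 1 within the scatter and together with it the highest of the three numbers; compound 2 gives 1 nM, a gap to compound 3 that also lies within the scatter. Among the compounds with values here, the one single-point step among the measured compounds, no change at the digits printed from compound 1 to compound 3 (within the scatter), shows that exchanging one aryl-bearing chain for another on the ester side left the number unchanged.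

Compound 4 `CCCc1nc(CC)c(C(=O)OCc2ccccc2-c2ccccc2)n1Cc1ccc(-c2ccccc2S(=O)(=O)NC(=O)OCCC(C)C)cc1F` differs from compound 3 in one place: 2-phenylphenyl in place of 3-phenoxypropyl on a saturated chain carbon bound to an oxygen next to a carbonyl group. The step from compound 1 to compound 3 bears on it only loosely, since compound 4 drops the chain altogether and carries the second ring directly on the first, much as compound 2 carries a further group on its benzyl ester and still gives 1 nM. All three ester groups measured give numbers within the scatter of one another, so no step beyond the scatter is expected in this assay. Compound 4 is therefore estimated at 1.5 nM (range 0.5 nM to 5 nM), which means an expected step of a 1.3-fold lower number from compound 3 to compound 4 (0.12 log units; within the scatter).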

Compound 4, half-maximal inhibitory concentration: 9 nM
Compound 4: the middle estimate sits 6.0-fold (0.78 log units) below what was measured, outside the stated range (above it).
By their numbers in this assay, from the lowest: compounds 2, 1 and 3 (each within the scatter of the next); then compound 4.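

In this assay, within the data shown here, the ester position proves not to be indifferent to the group it carries: the earlier compounds stood within the scatter of one another, but 2-phenylphenyl in place of 3-phenoxypropyl gives a 4.5-fold higher number from compound 3 to compound 4 (0.65 log units; beyond the scatter) and is beyond the scatter, as is the matching change with a 4.5-fold higher number from compound 1 to compound 4 (0.65 log units; beyond the scatter) in the same direction. Phenyl in place of benzamido on an aromatic carbon gives a 9.0-fold higher number from compound 2 to compound 4 (0.95 log units; beyond the scatter) and is also beyond the scatter, so the group on that aromatic carbon matters as well, though all three steps remain modest. Nothing measured here accounts for these higher numbers.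

The compounds shown leave open whether a plain phenyl ester or a simple ethyl ester would stay level with compound 3. They also leave open how an amine or a carboxylic acid at the end of the ester chain would read.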